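This account rests on a few compounds, and the source may have more. Where it says the series, first, only, none or still open, it means among the compounds named here.

Of the compounds shown here, three have been measured in an assay on isolated protein for inhibition of Amine oxidase [flavin-containing] B (Homo sapiens) (on this read-out higher numbers stand for weaker inhibition and lower numbers for stronger inhibition), so far. Compound 1, `CCNC(=S)N1N=C(c2ccc(OC)cc2)CC1c1cccs1`, gives 22000 nM. Compound 2, `COc1cc(O)ccc1O`, gives 8900 nM. Compound 3, `COc1ccc(C2=NN(C(C)=O)C(c3ccccc3C)C2)c(OC)c1`, gives 40000 nM. Among these three numbers compound 1 stands second highest; its value and that of compound 3 lie within the usual scatter of each other, so no order can be read between them, whereas compound 2 shows the lower number, and that gap goes beyond the scatter. Within the data shown here, no pair of these measured compounds differs in a single place, so no step between them can be drawn.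

Compound 4, `C=CNC(=S)N1N=C(c2ccc(OC)cc2)CC1c1cccs1`, has not yet been measured in this assay. It differs from compound 1 in one place: vinyl in place of ethyl on an amide-type nitrogen. Among the measured compounds shown here, nothing among the measured compounds speaks to this kind of exchange, so the expected step from compound 1 to compound 4 in this assay, no change at the digits printed from compound 1 to compound 4 (within the scatter), is none beyond the scatter. The value of compound 4 in this assay is accordingly estimated at 22000 nM, expected to fall between 8000 nM and 60000 nM.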

Compound 4, half-maximal inhibitory concentration: 65000 nM
Compound 4: the middle estimate sits 3.0-fold (0.47 log units) below what was measured; the whole stated range lies below it.
By their numbers in this assay, from the lowest: compound 2; then compounds 1, 3 and 4 (each within the scatter of the next, the first and the last beyond it).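

In this assay, vinyl in place of ethyl on the amide-type nitrogen gives a 3.0-fold higher number from compound 1 to compound 4 (0.47 log units; beyond the scatter), a modest loss of inhibition. This shows that the position is sensitive to a small exchange: both groups have the same count of heavy atoms, and the listed difference is the one double bond outside aromatic rings, yet the two numbers lie apart beyond the scatter. Nothing in the available data explains why this exchange weakens inhibition.

On these data alone, whether a longer chain such as propyl, or a ring such as cyclopropyl, on this nitrogen would give a lower or higher number than ethyl remains open. A single step also cannot show whether the same exchange would act alike on a different core.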